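The compounds below may be only part of what the source reports. "The series", "measured", "known", "first", "only" and "open" are said of these compounds alone.

Values in a functional assay on HEK293 cells (Homo sapiens) for cytotoxicity; on this read-out lower numbers stand for higher toxicity in this test and higher numbers for lower toxicity in this test:
- Compound 1 `COc1ccc([C@H]2CC(=O)N(C(C)=O)C2)cc1OC1CCCC1`: > 10000 nM
- Compound 2 `COc1ccc([C@H]2CC(=O)N(c3cccc(C#N)c3)C2)cc1OC1CCCC1`: > 10000 nM
- Compound 3 `COc1ccc([C@H]2CC(=O)N(c3cccc(C(F)(F)F)c3)C2)cc1OC1CCCC1`: > 10000 nM

Compound 3 stands at > 10000 nM, which is a limit of the assay and not a number. Compound 4 `COc1ccc([C@H]2CC(=O)N(c3ccc(S(C)(=O)=O)cc3)C2)cc1OC1CCCC1` differs from compound 3 in one group, with 4-(methylsulfonyl)phenyl in place of 3-(trifluoromethyl)phenyl on an amide-type nitrogen in a ring.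

Among the compounds with values here, three measured steps bear on this change: a step that the two limits leave unreadable from compound 1 to compound 2, a step that the two limits leave unreadable from compound 1 to compound 3 and a step that the two limits leave unreadable from compound 2 to compound 3. None of them has a readable size, so they show no direction. Acetyl, 3-cyanophenyl and 3-(trifluoromethyl)phenyl on that nitrogen all end at the same limit in this assay.

Compound 4 is therefore expected to be reported as a limit too, going by compound 3 and (the limit of > 10000 nM in this assay, at which 3 of the 3 values shown sit). The expected step is a step that the limit leaves unreadable from compound 3 to compound 4, with no direction expected beyond the scatter. For compound 4 the estimated value is 15000 nM, in an expected range from 6000 nM to 40000 nM.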

Compound 4, half-maximal cytotoxic concentration: > 10000 nM
Compound 4: no number, only a limit (the forecaster's own chance of this, stated with the estimate: 85%); the middle value does not contradict the limit.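

In this assay compound 4 gives > 10000 nM, a limit of the assay and not a number. Within the data shown here, no step from compound 1, compound 2 or compound 3 to compound 4 can be read. The compounds shown leave open whether these groups on the nitrogen change toxicity in this test at all: the limit of > 10000 nM in this assay, at which 4 of the 4 values shown sit.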